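The source may report more compounds than this note shows. Statements on the series, on what has been measured and on what is new or still open speak of the compounds shown alone.

Compound 1 `O=Cc1cn(-c2ccccc2)nc1-c1ccc(Cl)cc1` is the smallest member of the set; in a functional assay on MCF7 cells (Homo sapiens) for antiproliferative activity, read by MTT assay, with a stated time of 24 h, tested at 0.0001 ug/mL (a lower number here means a stronger effect, a higher number a weaker effect of the compound at the concentration tested), compound 1 gives 100%. Compound 2 `COc1cc(/C=C/C(=O)C(=Cc2cn(-c3ccccc3)nc2-c2ccc([N+](=O)[O-])cc2)C(=O)/C=C/c2ccc(O)c(OC)c2)ccc1O`, a far larger molecule built around the same core and carrying a 4-nitrophenyl on the aromatic carbon, in this assay gives 98%. Compound 3 `COc1cc(/C=C/C(=O)C(=Cc2cn(-c3ccccc3)nc2-c2ccccc2O)C(=O)/C=C/c2ccc(O)c(OC)c2)ccc1O` bears a 2-hydroxyphenyl in that place, and in this assay compound 3 gives 100%. The step of a number 2 percentage points higher from compound 2 to compound 3 (within the scatter) lies within the scatter, so compounds 2 and 3 cannot be ordered against each other. Compound 3 thus stands level with compound 1 to the digit given and within the scatter of compound 2; all three numbers sit together at the top of the range seen, and none can be called stronger or weaker than another.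

Compound 4 `COc1cc(/C=C/C(=O)C(=Cc2cn(-c3ccccc3)nc2-c2cccc([N+](=O)[O-])c2)C(=O)/C=C/c2ccc(O)c(OC)c2)ccc1O` is the next member. It differs from compound 3 in one place: 3-nitrophenyl in place of 2-hydroxyphenyl on an aromatic carbon. Among the measured compounds shown here, only one measured step bears on this position, the exchange of the aryl group from compound 2 to compound 3, and it produced no movement beyond the scatter. A nitrophenyl and a hydroxyphenyl in that place gave essentially the same read-out, so the step of a number 1 percentage points lower from compound 3 to compound 4 (within the scatter) is expected to show no change beyond the scatter. Compound 4 is therefore expected to give about 99% in this assay, with a likely range from 92% to 105%.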

Compound 4, a percentage reported as activity, at one concentration (the size of the read-out at that concentration, not a potency): 99%
Beside the measured number, compound 4's estimate shows no gap at the digits printed; the range from low to high includes it.
By their numbers in this assay, from the lowest: compounds 2, 4, 1 and 3 (each within the scatter of the next).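

Among the compounds shown here, compound 4 adds a comparison the earlier compounds could not give, two nitrophenyl groups that differ only in where the nitro group sits on the phenyl ring, and the exchange of 4-nitrophenyl for 3-nitrophenyl is a number 1 percentage points higher from compound 2 to compound 4 (within the scatter) in this assay. The exchange of 2-hydroxyphenyl for 3-nitrophenyl, which gives up the hydrogen-bond donor of the hydroxyphenyl and brings in an extra hydrogen-bond acceptor, is a number 1 percentage points lower from compound 3 to compound 4 (within the scatter), so at this aromatic carbon of the shared core, neither the place of the nitro group nor the choice between these groups separates the compounds in this assay. No measurement at hand offers any explanation for this lack of separation.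

The compounds shown leave open whether an aminophenyl, a carboxyphenyl or a phenyl carrying a longer chain in this place would move the read-out beyond the scatter. They also leave open whether the three aryl groups would separate at a higher concentration, since a single concentration gives the size of the read-out and not a potency.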